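A few compounds are considered here, and "the series" means these few. Any claim that something is new, unique, unknown or untested is made for them only; others in the source may bear on it.

Measured so far in a functional assay on DU-145 cells (Homo sapiens) for cytotoxicity, read by XTT assay, with a stated time of 72 h; a lower number here means a stronger inhibitor, a higher number a weaker inhibitor:
- compound 1 `Clc1ccc(/C=N/Nc2nc(-c3ccccc3)c[se]2)cc1`: 54200 nM
- compound 2 `CC(=O)c1[se]c(N/N=C/c2csc(-c3ccccc3)n2)nc1C`: 49900 nM
- compound 3 `CC(=O)N(/N=C/c1ccc(Cl)cc1)c1nc(-c2ccccc2)c[se]1`: a limit of the assay, > 62000 nM, not a number

Compound 1 and compound 3 share one core and differ by acetyl in place of hydrogen on a nitrogen on an aromatic ring. The step is an at least 1.1-fold higher number from compound 1 to compound 3 (0.05 log units; that floor lies within the scatter). It has only a floor because compound 3 sits at the limit of > 62000 nM in this assay, at which 1 of the 3 values shown sits. Compound 2 carries a different core; the difference between the two cores is not broken down here. The values of compound 1 and compound 2 lie within the usual scatter of each other, so no order between them is claimed.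

Compound 4 `CC(=O)c1[se]c(N(/N=C/c2csc(-c3ccccc3)n2)C(C)=O)nc1C` is not yet measured. For the measured compounds named here, it differs from compound 2 by acetyl in place of hydrogen on a nitrogen on an aromatic ring, the same change in the same surroundings as the one from compound 1 to compound 3. The expected step is a 1.4-fold higher number from compound 2 to compound 4 (0.15 log units; within the scatter), resting on the measured step of an at least 1.1-fold higher number from compound 1 to compound 3 (0.05 log units; that floor lies within the scatter). Compound 4 is expected to give 70000 nM in this assay, estimated between 40000 nM and 130000 nM, with a real chance that only a limit is reported.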

Compound 4, half-maximal inhibitory concentration: 31300 nM
Compound 4: middle estimate off by 2.2-fold (0.35 log units), on the high side, and the stated range ends above it.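

In this assay, for the compounds shown here, acetyl in place of hydrogen on a nitrogen on an aromatic ring gives a 1.6-fold lower number from compound 2 to compound 4 (0.20 log units; within the scatter), so on the core of compound 2 the change produces no step that can be told from the usual scatter, and no order between these two compounds is claimed. Whether the change carries from one core to the other is neither confirmed nor ruled out, and no difference between the two cores' responses is established: the same change on two cores in this assay, an at least 1.1-fold higher number (0.05 log units; that floor lies within the scatter) from compound 1 to compound 3 and a 1.6-fold lower number (0.20 log units; within the scatter) from compound 2 to compound 4; the limit leaves it open whether they differ. Compound 3 gives > 62000 nM, which is a limit of the assay and not a number.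

The compounds shown leave open whether a different group on the same nitrogen, such as a longer acyl chain like propanoyl, a simple methyl or a group carrying an amine or a carboxylic acid, would move the number beyond the scatter on either core. They also leave open whether the acetyl step would look the same on any core beyond these two.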